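Vinyl in place of isopropyl on the shared core

This account rests on a few compounds, and the source may have more. Where it says the series, first, only, none or still open, it means among the compounds named here.

In a functional assay on HOS cells (Homo sapiens) for antiproliferative activity, read by sulforhodamine B assay (a higher number here means a weaker inhibitor of growth, a lower number a stronger inhibitor of growth), compound 1 (`C[C@@H]1O[C@H](COCc2ccccc2)[C@@H](OCc2ccccc2)[C@H](OCc2ccccc2)C1=O`) gives > 50000 nM, which is a limit. Compound 2 (`CC[C@@H]1O[C@H](COCc2ccccc2)[C@@H](OCc2ccccc2)[C@H](OCc2ccccc2)C1=O`) gives a true reading of 4300 nM. Compound 3 (`CC(C)C[C@@H]1O[C@H](COCc2ccccc2)[C@@H](OCc2ccccc2)[C@H](OCc2ccccc2)C1=O`) gives > 50000 nM, also a limit and not a number.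

Compound 4 (`C=CC[C@@H]1O[C@H](COCc2ccccc2)[C@@H](OCc2ccccc2)[C@H](OCc2ccccc2)C1=O`) differs from compound 3 by vinyl in place of isopropyl on a saturated chain carbon bound to a saturated ring carbon. Two measured steps at this place bear on it: an at least 11-fold lower number from compound 1 to compound 2 (1.06 log units; beyond the scatter), and an at least 11-fold higher number from compound 2 to compound 3 (1.06 log units; beyond the scatter). Both are large, and they run in opposite directions. A moderate move towards a lower number in this assay is therefore expected, an at least 4.1-fold lower number from compound 3 to compound 4 (0.61 log units; beyond the scatter). For compound 4 the estimate is 12000 nM, with an expected range of 3000 nM to 50000 nM.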

Compound 4, concentration for 50% growth inhibition: 7600 nM
For compound 4 the middle estimate is 1.6-fold (0.20 log units) above the measured one; the measured number falls inside the stated range.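

In this assay, for the compounds shown here, methyl is no longer the only group at this place with a readable value: vinyl in place of isopropyl gives an at least 6.5-fold lower number from compound 3 to compound 4 (0.81 log units; beyond the scatter), and vinyl in place of hydrogen gives an at least 6.5-fold lower number from compound 1 to compound 4 (0.81 log units; beyond the scatter). Vinyl in place of methyl gives a 1.8-fold higher number from compound 2 to compound 4 (0.25 log units; within the scatter), so these two groups cannot be told apart in this read-out. Compound 1 and compound 3 remain limits, not numbers: the limit of > 50000 nM in this assay, at which 2 of the 4 values shown sit.

On these data alone, how growth inhibition responds to a longer chain, an amine or a carboxylic acid at this place stays open.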